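The source may hold more compounds than are shown below. What is called first, only, known or untested is meant among the compounds shown, and "the series" means these compounds.

Measured so far in a functional assay on MCF7 cells (Homo sapiens) for antiproliferative activity, read by sulforhodamine B assay, with a stated time of 48 h; on this read-out lower numbers stand for stronger inhibition and higher numbers for weaker inhibition:
Compound 1 `Cc1ccc(NS(=O)(=O)c2ccc(N3CCNC3=O)cc2)cc1` gives 610 nM
Compound 2 `CCc1cccc(NS(=O)(=O)c2ccc(N3CCNC3=O)cc2)c1` gives 130 nM
Compound 3 `O=C1NCCN1c1ccc(S(=O)(=O)Nc2ccc(Br)cc2)cc1` gives 240 nM

Compound 3 stands with compound 2 and apart from compound 1. One gap is a 1.8-fold higher number from compound 2 to compound 3 (0.27 log units; within the scatter), and the other is a 2.5-fold lower number from compound 1 to compound 3 (0.41 log units; beyond the scatter). Compound 4 `Cc1ccccc1NS(=O)(=O)c1ccc(N2CCNC2=O)cc1` has not yet been measured. It keeps the shared core and carries 2-methylphenyl in place of 4-bromophenyl on a sulfonamide nitrogen.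

Among the measured compounds shown here, two measured steps bear on this change. The step with bromo in place of methyl was a 2.5-fold lower number from compound 1 to compound 3 (0.41 log units; beyond the scatter), so a methyl-bearing ring in compound 4 points towards a higher number, although compound 1 carries its methyl as 4-methylphenyl. The step to 3-ethylphenyl was a 4.7-fold lower number from compound 1 to compound 2 (0.67 log units; beyond the scatter), which shows that compounds with a carbon chain on the ring can differ modestly from one another. For the measured compounds named here, no measured compound carries 2-methylphenyl, so the direction is only tentative. In this assay a small step towards a higher number is therefore expected, and the estimated step is a 1.9-fold higher number from compound 3 to compound 4 (0.27 log units; within the scatter). For compound 4 the estimated value is 450 nM, with an expected range from 150 nM to 1300 nM.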

Compound 4, half-maximal inhibitory concentration: 280 nM
Beside the measured number, compound 4's estimate is 1.6-fold (0.21 log units) above it, within the range that was stated.
By their numbers in this assay, from the lowest: compounds 2, 3 and 4 (each within the scatter of the next, the first and the last beyond it); then compound 1.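

In this assay, the change from 4-bromophenyl to 2-methylphenyl on the sulfonamide nitrogen is small (a 1.2-fold higher number from compound 3 to compound 4 (0.07 log units; within the scatter)), which shows that a methyl-bearing ring at this position need not give a number as high as that of compound 1. Among the compounds shown here, the new compound also gives the first comparison of one substituent placed differently on this ring, and 2-methylphenyl in place of 4-methylphenyl is a modest step (a 2.2-fold lower number from compound 1 to compound 4 (0.34 log units; beyond the scatter)), while 2-methylphenyl in place of 3-ethylphenyl is a modest step in the other direction (a 2.2-fold higher number from compound 2 to compound 4 (0.33 log units; beyond the scatter)). Thus, among these four compounds, the result at this position depends on more than the presence of a methyl group, but no measurement at hand explains why these aryl groups differ.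

The compounds shown leave open how a phenyl ring bearing an amine or a carboxylic acid would behave at this position. They also leave open whether a longer chain than the ethyl group of compound 2 would keep or lose the low number of that compound.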